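Acetyl to ethyl on oxygen: working notes

A few compounds are considered here, and "the series" means these few. Any claim that something is new, unique, unknown or untested is made for them only; others in the source may bear on it.

Measured so far in an ADME assay on LLC-PK1 cells (Sus scrofa) for cytotoxicity, read by neutral red uptake (a higher number here means a weaker inhibitor, a lower number a stronger inhibitor), for two compounds:
- compound 1 `CC(=O)OC(/C=C/c1ccccc1)=C1\C(=O)C=C(C)C1=O` gives 4.9 ug/mL on the read-out
- compound 2 `COC(/C=C/c1ccc(Cl)cc1)=C1\C(=O)C=C(C)C1=O` gives 3.1 ug/mL on the read-out

With only these two numbers, the position of compound 1 is easily stated: its 4.9 ug/mL lies within the usual scatter of the value for compound 2 at 3.1 ug/mL in the same test, so the pair cannot be ranked.

The next compound to be tested is compound 3 `CCOC(/C=C/c1ccccc1)=C1\C(=O)C=C(C)C1=O`, which carries ethyl in place of acetyl on an oxygen on an unsaturated carbon, with the rest of the core of compound 1 unchanged: ethyl in place of acetyl on an oxygen on an unsaturated carbon is the full count of the change. Within the data shown here, no measured pair isolates this change, so the data offer no step to carry over. Among the measured compounds shown here, the only guide is the narrow spread of the two values above. No step beyond the scatter is therefore expected in this assay, and no firm direction is expected either. The expected outcome is a 1.2-fold lower number from compound 1 to compound 3 (0.09 log units; within the scatter) as an estimate only. For compound 3 the estimated value is 4 ug/mL, with an expected range from 1.8 ug/mL to 9 ug/mL in this test.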

Compound 3, half-maximal inhibitory concentration: 4 ug/mL
Estimate against measurement, compound 3: no gap at the digits printed, within the range that was stated.
By their numbers in this assay, from the lowest: compounds 2, 3 and 1 (each within the scatter of the next).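

Among these compounds, the single change from acetoxy to ethoxy on this oxygen can now be read in this assay as a 1.2-fold lower number from compound 1 to compound 3 (0.09 log units; within the scatter) and stays within the scatter. At this place, then, a group with a carbonyl and a group without one cannot be told apart in this read-out: with ethyl, compound 3 gives 4 ug/mL and sits with compound 1 at 4.9 ug/mL in the same narrow band. No measurement on any property of these groups is available to account for this, so the result stands as an observation only.

Steps to compound 2 cannot be read, since it differs from compound 1 and compound 3 in more than one place, and the effect of the group on this oxygen therefore rests on one pair in one assay. Open questions are whether a longer chain such as butyl, or a group carrying an amine or a carboxylic acid, on the same oxygen would also stay within the scatter of compound 1, and whether the same holds with the other substituent on the shared core found in compound 2.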